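Shortening the Chain: Estimating Compound 3

The compounds below may be only part of what the source reports. "The series", "measured", "known", "first", "only" and "open" are said of these compounds alone.

Among the compounds with values here, compound 2 `CCCCCCOC(=O)Nc1ccc([Se]C#N)cc1` gives 46200 nM in a functional assay on CCRF-CEM cells (Homo sapiens) for cytotoxicity, read by MTT assay, with a stated time of 72 h; a higher number here means a weaker inhibitor of growth, a lower number a stronger inhibitor of growth; the only other measured compound, compound 1 `CC(C)COC(=O)Nc1ccc([Se]C#N)cc1`, gives 38300 nM, a gap within the scatter. Compound 3 `CCOC(=O)Nc1ccc([Se]C#N)cc1` has not been measured; it differs from compound 2 by hydrogen in place of butyl on a saturated chain carbon, two bonds along the chain from an oxygen next to a carbonyl group. Within the data shown here, the one measured step that bears on such a change in chain length, a 1.2-fold higher number from compound 1 to compound 2 (0.08 log units; within the scatter), stayed within the scatter, so the expected step, a 1.1-fold lower number from compound 2 to compound 3 (0.04 log units; within the scatter), is likewise small, with no direction beyond the scatter. Compound 3 is therefore estimated at 42000 nM, within a range from 20000 nM to 85000 nM.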

Compound 3, concentration for total growth inhibition: 39100 nM
For compound 3 the middle estimate is 1.1-fold (0.03 log units) above the measured one; low and high end bracket the measured number.
By their numbers in this assay, from the lowest: compounds 1, 3 and 2 (each within the scatter of the next).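

Going from hexyl to ethyl gives a 1.2-fold lower number from compound 2 to compound 3 (0.07 log units; within the scatter) in this assay, so this shortening of the chain produces no change that can be told from the scatter. Methyl in place of isopropyl gives a 1.0-fold higher number from compound 1 to compound 3 (0.01 log units; within the scatter) as well, so compound 1 with its branched chain and compound 3 with its short straight chain also cannot be told apart. From the compounds shown here alone, whether a chain ending in an amine or a carboxylic acid would move the number at this place remains open. No measured evidence accompanies these results to account for them.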